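The compounds below may be only part of what the source reports. "The series", "measured", "known", "first", "only" and "open" are said of these compounds alone.

Measured so far:
Compound 1, `Cc1cccc2sc(NC(=O)CCN3CCN(C(C)(C)C)CC3)nc12`, 200 nM
Compound 2, `Cc1cccc2sc(NC(=O)CCN3CCN(CC4CCCCC4)CC3)nc12`, 519 nM

Both compounds were tested in an assay on membranes from liver for displacement of a labelled ligand from Sigma intracellular receptor 2 (Rattus norvegicus), read by scintillation counting, with a stated time of 120 min; a lower number here means a stronger inhibitor, a higher number a weaker inhibitor. Among the two numbers, compound 2 stands at the higher one; the one step that separates it from compound 1 runs a 2.6-fold higher number from compound 1 to compound 2 (0.41 log units; beyond the scatter) and corresponds to swapping the group on the ring nitrogen.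

Compound 3, `Cc1cccc2sc(NC(=O)CCN3CCN(c4ccccn4)CC3)nc12`, has not yet been measured. It differs from compound 2 in one place: pyridin-2-yl in place of cyclohexylmethyl on an amine nitrogen in a ring. Among the measured compounds shown here, the single measured step bears on this only loosely, since it shows that a change at this same ring nitrogen moved the number a modest amount. For the measured compounds named here, there is no measured example of an aromatic group at this position, so the direction of the new step is open. Compound 3 is therefore expected to land near compound 2, with the step of a 1.3-fold lower number from compound 2 to compound 3 (0.11 log units; within the scatter) estimated to stay within or close to the scatter. The estimate for compound 3 is 400 nM, with a range from 120 nM to 1500 nM.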

Compound 3, inhibition constant: > 1000 nM
Compound 3: a limit, no number; the forecaster's own chance of this, stated with the estimate: 5%; middle value at least 2.5-fold (0.39 log units) from the limit.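

Compound 3 reaches only a limit, not a number, in this assay: the limit of > 1000 nM in this assay, at which 1 of the 3 values shown sits. Measured against the cyclohexylmethyl group, pyridin-2-yl gives an at least 1.9-fold higher number from compound 2 to compound 3 (0.28 log units; that floor lies within the scatter), so this comparison alone does not fix how far apart the two compounds lie. Measured against the tert-butyl group, it gives an at least 5.0-fold higher number from compound 1 to compound 3 (0.69 log units; beyond the scatter), which shows that placing an aromatic ring directly on this ring nitrogen can clearly weaken binding, something the two earlier groups, neither of them aromatic, could not show.

The compounds shown do not reveal how far the number for compound 3 lies past its limit. They also leave open whether the loss belongs to aromatic rings in general, as a phenyl or benzyl group would test, or to the ring nitrogen of pyridin-2-yl, as a comparison with phenyl would help to separate.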